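The source may hold more compounds than are shown below. What is called first, only, known or untested is meant among the compounds shown, and "the series" means these compounds.

Compound 1, `CCOC(=O)c1c(-c2cccc(F)c2)[nH]c2cc(OC)ccc2c1=O`, compound 2, `CCOC(=O)c1c(-c2cccc(Cl)c2)[nH]c2cc(OC)ccc2c1=O`, and compound 3, `CCOC(=O)c1c(-c2cccc(-c3ccccc3)c2)[nH]c2cc(OC)c(Cl)cc2c1=O`, were tested in an ADME assay on BJ cells (Homo sapiens) for cytotoxicity, read by luminescence, with a stated time of 72 h; on this read-out lower numbers stand for an effect already at smaller amounts and higher numbers for an effect only at larger amounts of compound. For compound 1 only a limit of the assay was obtained, > 21500 nM. For compound 2 the result is also a limit, > 21500 nM. For compound 3 the result is again a limit, > 21500 nM. All three rest at the limit of > 21500 nM in this assay, at which 3 of the 3 values shown sit. The change fluoro in place of chloro on an aromatic carbon therefore gives a step that the two limits leave unreadable from compound 2 to compound 1. The difference between the cores of compound 2 and compound 3 is not broken down here. Compound 4, `CCOC(=O)c1c(-c2cccc(-c3ccccc3)c2)[nH]c2cc(OC)c(F)cc2c1=O`, differs from compound 3 by fluoro in place of chloro on an aromatic carbon, the same kind of change as from compound 2 to compound 1, but here on a ring that is part of a fused or bridged system of two rings, ortho to a methoxy group, meta and para to a fused ring. Since compound 3 sits at the limit of > 21500 nM in this assay, at which 3 of the 3 values shown sit, compound 4 is expected to show a number no higher from compound 3 to compound 4 (the limit leaves the size open). Compound 4 is estimated in this assay at 21500 nM, most likely again as a limit.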

Compound 4, half-maximal effective concentration: > 21500 nM
Compound 4: no number, only a limit; the forecaster's own chance of this, stated with the estimate: 85%; the middle value lies on the limit itself.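

Compound 3 and compound 4 both give only a limit in this assay, and the step between them cannot be read. The compounds shown leave open at what concentration any of them would show an effect.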